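The source may report more compounds than this note shows. Statements on the series, on what has been measured and on what is new or still open speak of the compounds shown alone.

Measured so far:
Compound 1, `CC(C)(C)c1ccc(Nc2cccc3c2C(=O)N(C2CCC(=O)NC2=O)C3=O)cc1`: 36%
Compound 2, `CCCc1ccc(Nc2ccc3c(c2)C(=O)N(C2CCC(=O)NC2=O)C3=O)cc1`: 10%

Of the compounds shown here, two sharing the same core have been tested in an assay on FRT-Jurkat cells for inhibition of nuclear factor NF-kappa-B complex (Homo sapiens), read by flow cytometry, with a stated time of 24 h, tested at 10 uM; a higher number here means more inhibition at the concentration tested (going by the name of the read-out), a lower number less inhibition. Compound 1 gives 36%, the higher of the two numbers. Compound 2 gives 10%, a number lower by a margin that lies beyond the usual scatter of such measurements. The two structures differ in more than one place, so nothing more can be read from this pair than what the two values show.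

The next compound, compound 3, `CC(C)c1ccc(Nc2cccc3c2C(=O)N(C2CCC(=O)NC2=O)C3=O)cc1`, keeps the core of compound 1 and changes only the group attached to the outer ring: hydrogen in place of methyl on a saturated chain carbon bound to an aromatic carbon and two saturated chain carbons. Read one bond further out, the tert-butyl becomes an isopropyl. Among the compounds with values here, this is a small change, and nothing among the measured compounds tells how the assay responds to it. In this assay a step of modest size is expected, if any, and it might go either way or stay within the scatter. The step from compound 1 to compound 3 is estimated at a number 8 percentage points lower from compound 1 to compound 3 (within the scatter). Compound 3 is therefore expected to give about 28%, most likely between 10% and 46%.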

Compound 3, a percentage reported as inhibition, at one concentration (the size of the read-out at that concentration, not a potency): 19%
The estimate for compound 3 lay 9 percentage points above the measured number, within the range that was stated.
By their numbers in this assay, from the lowest: compounds 2 and 3 (each within the scatter of the next); then compound 1.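

Within the data shown here, compound 1 and compound 3 differ in one place only, so this is the first comparison in this assay that can be tied to a single change, and the step is a number 17 percentage points lower from compound 1 to compound 3 (beyond the scatter) when hydrogen takes the place of methyl on a saturated chain carbon bound to an aromatic carbon and two saturated chain carbons. A single carbon, with no ring, no charge and no hydrogen-bond donor or acceptor entering or leaving, is therefore enough at this place to move the reading by more than the usual scatter, with the tert-butyl compound giving the higher number of this pair. Nothing measured here shows why this change lowers the number.

This is one step at one concentration, so it leaves open whether the number would keep falling as the group on the outer ring is trimmed further, for example to an ethyl or a methyl, or would recover with a cyclopropyl or a longer chain. It also leaves open how the assay would answer a group of a different kind at this place, such as an amine or a carboxylic acid.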